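Methoxy Added to Compound 2: An Expected Weakening

This account rests on a few compounds, and the source may have more. Where it says the series, first, only, none or still open, it means among the compounds named here.

Compound 2 `CCN1C(=O)N(CC)C2C1NC(=S)N2/N=C/C=C/c1ccccc1` holds the only numerical result in a functional assay on A549 cells (Homo sapiens) for inhibition, read by MTT assay, with a stated time of 72 h (a lower number here means a stronger inhibitor, a higher number a weaker inhibitor), where compound 2 gives 6530 nM. Compound 1 `COc1ccc(/C=C/C=N/N2C(=S)NC3C2N(C)C(=O)N3C)cc1` reaches only a limit of that assay: in this assay compound 1 gives > 100000 nM. Compound 3 `CCN1C(=O)N(CC)C2C1NC(=S)N2/N=C/C=C/c1ccc(OC)cc1` differs from compound 2 by methoxy in place of hydrogen on an aromatic carbon. Going by the values given here, no measured pair shows this change directly, but compound 1, which also carries a methoxy group, sits at the limit of > 100000 nM in this assay, at which 1 of the 2 values shown sits, so a step toward weaker inhibition beyond the scatter seems likely. Compound 3 is therefore expected to give 20000 nM in this assay, with a range of 5000 nM to 100000 nM. The expected step is a 3.1-fold higher number from compound 2 to compound 3 (0.49 log units; beyond the scatter).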

Compound 3, half-maximal inhibitory concentration: 17200 nM
Beside the measured number, compound 3's estimate is 1.2-fold (0.07 log units) above it; measured number inside the range.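

Until now this change could only be estimated; compound 3 measures it directly. In this assay methoxy in place of hydrogen on the aromatic ring, para to a large group, gives a 2.6-fold higher number from compound 2 to compound 3 (0.42 log units; beyond the scatter) and so shows a modest weakening. Inhibition remains measurable with this group in place.

From the compounds shown here alone, what an amine or a carboxylic acid would do at this position stays open, as does the effect of methoxy elsewhere on the ring. Compound 1 gives no number to set beside these results, only a limit: the limit of > 100000 nM in this assay, at which 1 of the 3 values shown sits.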